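This account rests on a few compounds, and the source may have more. Where it says the series, first, only, none or still open, it means among the compounds named here.

Compound 1 `C/N=C(/S)[C@@]1(c2cccnc2)CCCC[C@@H]1CC#N` was examined in a functional assay (aorta) with Rattus norvegicus as the target (a lower number here means a stronger inhibitor, a higher number a weaker inhibitor), where compound 1 gives 300 nM. Two related compounds were measured beside it: compound 2 `C/N=C(/S)[C@@]1(c2cccnc2)CCCC[C@@H]1CCNS(=O)(=O)c1ccc([N+](=O)[O-])cc1`, which in this assay gives 300 nM, and compound 3 `CNC(=S)[C@@]1(c2cccnc2)CCCC[C@@H]1CCNS(=O)(=O)c1ccc(OC)cc1`, which in this assay gives 300 nM. On these numbers compound 1 stands level with compound 2 and with compound 3 at the digits shown; no separation among the three lies beyond the usual scatter of repeated measurements, so none of them can be called the stronger or weaker inhibitor.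

Compound 4 `C/N=C(/S)[C@@]1(c2cccnc2)CCCC[C@@H]1CCNC(=O)C(C)C` has not yet been measured in this assay. It differs from compound 1 in one place: ((isopropylcarbonyl)amino)methyl in place of cyano on a saturated chain carbon bound to a saturated ring carbon. Within the data shown here, no step between measured compounds that differ in a single place is available to guide the expectation. Compound 2 carries a different substituent on a saturated chain carbon bound to a saturated ring carbon and gives 300 nM, which supports no change beyond the scatter. The step of no change at the digits printed from compound 1 to compound 4 (within the scatter) is therefore expected to be small, in no particular direction. Compound 4 is estimated to give about 300 nM in this assay, with a range from 100 nM to 1000 nM.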

Compound 4, concentration for 90% inhibition: 300 nM
Estimate against measurement, compound 4: no gap at the digits printed; the range from low to high includes it.
By their numbers in this assay, from the lowest: compounds 1, 2, 3 and 4 (each within the scatter of the next).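

In this assay, among these compounds, the exchange of cyano for ((isopropylcarbonyl)amino)methyl on a saturated chain carbon bound to a saturated ring carbon gives no change at the digits printed from compound 1 to compound 4 (within the scatter), and this is the first step at this position that can be read as a change in one place. The entering group brings 7 heavy atoms in place of 2 and 1 hydrogen-bond donor where cyano has none, so a much larger group at this position leaves the read-out unmoved. Nothing measured here explains this result. The compounds shown leave open whether any group at this position would move the value, since none of them separates from the others. A free amine or a carboxylic acid at the end of the chain, or a longer chain, would test this further.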